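Compound 3 Awaits Testing After a Benzamido to Acetamido Change

A few compounds are considered here, and "the series" means these few. Any claim that something is new, unique, unknown or untested is made for them only; others in the source may bear on it.

In a functional assay on cells (Homo sapiens) for inhibition, read by MTT assay, with a stated time of 72 h (a higher number here means a weaker inhibitor, a lower number a stronger inhibitor), compound 2 (`CCOC(=O)Cn1ncc2c(Nc3ccc(NC(=O)c4ccccc4)cc3)ncnc21`) gives > 100 ug/mL as its result, a limit of the assay and not a number. Compound 1 (`CC(=O)Nc1ccc(Nc2ncnc3c2cnn3CC(=O)O)cc1`), which also carries an acetamido group, gives > 64 ug/mL as its result, likewise a limit. Compound 3 (`CCOC(=O)Cn1ncc2c(Nc3ccc(NC(C)=O)cc3)ncnc21`) differs from compound 2 as benzamido to acetamido, methyl in place of phenyl on a carbonyl carbon. Going by the values given here, no measured step shows the effect of this change in this assay and none beyond the scatter is expected, so the estimated move an at least 1.1-fold lower number from compound 2 to compound 3 (0.04 log units; that floor lies within the scatter) is small. For compound 3 the expected value is 90 ug/mL with an estimated range from 40 ug/mL to 200 ug/mL in this measurement.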

Compound 3, half-maximal inhibitory concentration: > 64 ug/mL
Compound 3 ended at the assay's limit; the forecaster's own chance of this, stated with the estimate: 70%; the middle value lies beyond the limit too.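

Compound 3, like compound 1 and compound 2, ends at a limit of this assay, so neither step to compound 3 can be read: the limit of > 64 ug/mL in this assay, at which 2 of the 3 values shown sit.

The compounds shown leave open whether methyl in place of phenyl on a carbonyl carbon, or ethyl in place of hydrogen on an oxygen next to a carbonyl group, alters inhibition at all.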